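A few compounds are considered here, and "the series" means these few. Any claim that something is new, unique, unknown or untested is made for them only; others in the source may bear on it.

Compound 1 `CN[C@@H]1CCN(c2cc3c(cc2F)c(=O)c(C(=O)O)cn3Cc2ccc(-c3ccccc3)cc2)C1`: 34800 nM
Compound 2 `O=C(O)c1cn(Cc2ccc(-c3ccccc3)cc2)c2cc(N3CC4CNCC4C3)c(F)cc2c1=O`: 33300 nM
Compound 3 `NC[C@@H]1CCN(c2cc3c(cc2F)c(=O)c(C(=O)O)cn3Cc2ccc(-c3ccccc3)cc2)C1`: 15600 nM

In an assay on isolated protein for inhibition of DNA topoisomerase 1 (Homo sapiens), with a stated time of 15 min (a higher number here means a weaker inhibitor, a lower number a stronger inhibitor), compound 3 has the lowest of the three numbers, but only by a modest margin: a 2.2-fold lower number from compound 1 to compound 3 (0.35 log units; beyond the scatter) and a 2.1-fold lower number from compound 2 to compound 3 (0.33 log units; beyond the scatter). Compound 4 `O=C(O)c1cn(Cc2ccc(-c3ccccc3)cc2)c2cc(N3C[C@H]4CCNC[C@H]4C3)c(F)cc2c1=O` is the next step from compound 3, and the change is a group of 9 heavy atoms (7 carbon, 2 nitrogen; one five-membered non-aromatic ring with 1 hetero atom, one six-membered non-aromatic ring with 1 hetero atom) in place of a group of 7 heavy atoms (5 carbon, 2 nitrogen; one five-membered non-aromatic ring with 1 hetero atom), on an aromatic carbon. Going by the values given here, the nearest precedent is a change of the same kind on the same aromatic carbon, a 1.0-fold lower number from compound 1 to compound 2 (0.02 log units; within the scatter), which stayed within the scatter, while the step of a 2.1-fold lower number from compound 2 to compound 3 (0.33 log units; beyond the scatter) was modest. The expected step is therefore small, a 1.4-fold higher number from compound 3 to compound 4 (0.15 log units; within the scatter), with no confident direction. The estimate for compound 4 in this assay is 22000 nM, with a range from 9000 nM to 55000 nM.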

Compound 4, half-maximal inhibitory concentration: 61000 nM
Estimate against measurement, compound 4: 2.8-fold (0.44 log units) below; the whole stated range lies below it.
By their numbers in this assay, from the lowest: compound 3; then compounds 2, 1 and 4 (each within the scatter of the next).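

On this aromatic carbon, the step of a 3.9-fold higher number from compound 3 to compound 4 (0.59 log units; beyond the scatter) is the largest seen so far in this assay, and it leaves the 3-(aminomethyl)pyrrolidin-1-yl group of compound 3 as the strongest of the four. The other two changes stay within the scatter: a 1.8-fold higher number from compound 2 to compound 4 (0.26 log units; within the scatter) and a 1.8-fold higher number from compound 1 to compound 4 (0.24 log units; within the scatter), so compound 3 alone stands apart. Nothing measured here explains this. Still open, from the compounds shown here alone, is whether a longer aminoethyl chain on the pyrrolidine ring would match or improve on aminomethyl. Going by these compounds, a piperazine ring at this carbon also remains untested in these compounds.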